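Cyanosulfanyl in Place of Bromo on the Shared Core

The compounds below may be only part of what the source reports. "The series", "measured", "known", "first", "only" and "open" are said of these compounds alone.

Compound 1 `COc1ccc(-c2nc3sc(Cc4ccc(Cl)cc4)nn3c2Br)cc1` gives 66000 nM in a functional assay on HeLa cells (Homo sapiens) for cytotoxicity, with a stated time of 72 h; on this read-out higher numbers stand for weaker inhibition and lower numbers for stronger inhibition. Compound 2 `Cc1ccc(-c2nc3sc(Cc4ccc(Cl)cc4)nn3c2Br)cc1` reaches only the assay limit of > 250000 nM in this assay. Compound 3 `Clc1ccc(Cc2nn3c(Br)c(-c4ccccc4)nc3s2)cc1` likewise sits at the limit of > 250000 nM. The steps of an at least 3.7-fold higher number from compound 1 to compound 2 (0.57 log units; beyond the scatter) and an at least 3.7-fold higher number from compound 1 to compound 3 (0.57 log units; beyond the scatter) are both read against (the limit of > 250000 nM in this assay, at which 2 of the 3 values shown sit), and the step that the two limits leave unreadable from compound 2 to compound 3 cannot be read. Going by the values given here, compound 2 thus stands at the limit, as does compound 3, with compound 1 the only numbered value. Compound 4 `Cc1ccc(-c2nc3sc(Cc4ccc(Cl)cc4)nn3c2SC#N)cc1` differs from compound 2 by cyanosulfanyl in place of bromo on an aromatic carbon. Among the compounds with values here, no measured step exchanges the bromo for another group, so none bears on this change, and no step beyond the scatter is expected in this assay. Compound 4 is expected at about 200000 nM, between 50000 nM and 600000 nM. The expected step is therefore an at least 1.2-fold lower number from compound 2 to compound 4 (0.09 log units; that floor lies within the scatter).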

Compound 4, half-maximal inhibitory concentration: 22000 nM
Estimate against measurement, compound 4: 9.1-fold (0.96 log units) above; the measured number lies below the stated range.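

Going by these compounds alone, at the position next to the ring nitrogen, which bears bromo in the earlier compounds, the group proves able to move the read-out in this assay: cyanosulfanyl in place of bromo gives an at least 11-fold lower number from compound 2 to compound 4 (1.05 log units; beyond the scatter). The earlier steps shown here exchanged only methoxy, methyl and hydrogen elsewhere, so none of them spoke to this position. The size of the new step is only a floor: the limit of > 250000 nM in this assay, at which 2 of the 4 values shown sit.

Going by these compounds, whether a thiol or an amine in place of bromo would lower the number as well stays open. So does whether the same exchange would lower it on the cores of compound 1 and compound 3.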